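A ring exchange on the saturated chain carbon

A few compounds are considered here, and "the series" means these few. Any claim that something is new, unique, unknown or untested is made for them only; others in the source may bear on it.

For the measured compounds named here, compound 2 `CC(C)C(c1ccc(-c2ccc3cccc(F)c3c2)[nH]c1=O)N1CCNC1=O` is the only compound of the pair that returned a number in an ADME assay on microsomes from liver (Rattus norvegicus) for metabolic stability; on this read-out lower numbers stand for a shorter-lived compound and higher numbers for a longer-lived compound; there compound 2 gives 0.283 h. Compound 1 `CCn1ncc2c(F)cc(-c3ccc(C(CC)(CC)c4ncn(C)n4)c(=O)[nH]3)cc21` stands apart, because in this assay compound 1 is recorded as > 3 h, and that is a limit of the assay rather than a measured number. Going by the values given here, the only evidence beyond the two values is the limit of > 3 h in this assay, at which 1 of the 2 values shown sits, so no measured step links the two compounds and nothing sizes any structural change on this read-out.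

Compound 3 `CC(C)C(/C=C1/CCNC1=O)c1ccc(-c2ccc3cccc(F)c3c2)[nH]c1=O` differs from compound 2 in one place: a group of 7 heavy atoms (5 carbon, 1 nitrogen, 1 oxygen; one five-membered non-aromatic ring with 1 hetero atom) in place of a group of 6 heavy atoms (3 carbon, 2 nitrogen, 1 oxygen; one five-membered non-aromatic ring with 2 hetero atoms), on a saturated chain carbon bound to an aromatic carbon and a saturated chain carbon. Among the compounds with values here, since no step between measured compounds is given, the size of this change cannot be read from the data, and the expectation stays close to compound 2, with no shift beyond the usual scatter claimed in either direction. For compound 3 the expected value in this assay is 0.25 h, within a range from 0.08 h to 0.8 h. This estimate means a step of a 1.1-fold lower number from compound 2 to compound 3 (0.05 log units; within the scatter), which is expected to stay inside the scatter of repeated measurements.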

Compound 3, half-life: 0.06 h
Compound 3: middle estimate off by 4.2-fold (0.62 log units), on the high side; measured number outside the range, below it.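

The exchange on the saturated chain carbon gives the only measured step among the compounds shown: in this assay, replacing the 2-oxoimidazolidin-1-yl group with the group carrying a five-membered non-aromatic ring with 1 hetero atom gives a 4.7-fold lower number from compound 2 to compound 3 (0.67 log units; beyond the scatter). This shows that the group at this position, on a saturated chain carbon bound to an aromatic carbon and a saturated chain carbon, can move the half-life beyond the scatter, even though both groups have the same counts of hydrogen-bond donors and acceptors and neither has a net charge. Nothing measured among these compounds indicates which difference between the two groups accounts for the step.

With only this one step, the compounds shown leave open whether the added double bond outside aromatic rings or the change in ring hetero atoms goes with the shorter half-life. They also leave open how a primary amine, a carboxylic acid or a longer alkyl chain on the same saturated chain carbon would stand in this assay.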